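The source may report more compounds than this note shows. Statements on the series, on what has been measured and on what is new or still open speak of the compounds shown alone.

Measured so far in a functional assay on HCT-116 cells (Homo sapiens) for cytotoxicity, read by MTT assay, with a stated time of 72 h; a lower number here means a stronger inhibitor, a higher number a weaker inhibitor:
Compound 1 `O=C(Nc1ccccc1)Nc1ccc(C(=O)NO)cc1` gives 14700 nM
Compound 2 `COc1ccc(NC(=O)Nc2ccc(C(=O)NO)cc2)cc1` gives 22300 nM
Compound 3 `O=C(/C=C/c1ccc(NC(=O)Nc2ccccc2)cc1)NO` gives 6490 nM

The lowest number of the three belongs to compound 3. Its closest neighbour is reached by a modest step (a 2.3-fold lower number from compound 1 to compound 3 (0.36 log units; beyond the scatter)), which puts 2-(hydroxycarbamoyl)ethenyl in place of hydroxycarbamoyl, and compound 2 lies further away still.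

Compound 4 `COc1ccc(NC(=O)Nc2ccc(/C=C/C(=O)NO)cc2)cc1` keeps everything in compound 3 except one spot, with methoxy in place of hydrogen on an aromatic carbon, para to a large group (methoxy in place of hydrogen on an aromatic carbon). One measured step makes this same swap (a 1.5-fold higher number from compound 1 to compound 2 (0.18 log units; within the scatter)), and it stays inside the scatter. That step was taken on a compound carrying hydroxycarbamoyl rather than the longer group, and one pair is thin evidence, so it may not carry over exactly. The step to compound 3 concerns a different place and only fixes the starting point. No step beyond the scatter is therefore expected, perhaps a slight drift towards a higher number. The estimated step is a 1.2-fold higher number from compound 3 to compound 4 (0.09 log units; within the scatter) and would be a small one. Compound 4 is expected at 8000 nM with an estimated range from 3800 nM to 17000 nM as the likely span.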

Compound 4, half-maximal inhibitory concentration: 11900 nM
Estimate against measurement, compound 4: 1.5-fold (0.17 log units) below, and the stated range covers the measured number.
By their numbers in this assay, from the lowest: compounds 3, 4, 1 and 2 (each within the scatter of the next, the first and the last beyond it).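

In this assay, turning phenyl into 4-methoxyphenyl on the core of compound 3 gives a 1.8-fold higher number from compound 3 to compound 4 (0.26 log units; within the scatter) and so the methoxy swap has now been read on two cores, neither reading leaving the scatter, and the two agree: the same change on two cores in this assay, a 1.5-fold higher number (0.18 log units; within the scatter) from compound 1 to compound 2 and a 1.8-fold higher number (0.26 log units; within the scatter) from compound 3 to compound 4, 1.2-fold (0.08 log units) apart, within the scatter of two such steps.

The other change, 2-(hydroxycarbamoyl)ethenyl in place of hydroxycarbamoyl, can now also be read on a second pair, where it gives a 1.9-fold lower number from compound 2 to compound 4 (0.27 log units; within the scatter) and stays within the scatter, while on the pair without methoxy it lay beyond it, yet the two steps themselves do not differ by more than the scatter: the same change on two cores in this assay, a 2.3-fold lower number (0.36 log units; beyond the scatter) from compound 1 to compound 3 and a 1.9-fold lower number (0.27 log units; within the scatter) from compound 2 to compound 4, 1.2-fold (0.08 log units) apart, within the scatter of two such steps.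

Across these four compounds, then, each change has about the same size whether or not the other is present, so the two look independent of each other.

Still open, on these data alone, is whether another group at this spot, such as an amine or a carboxylic acid, would give a step beyond the scatter where methoxy does not. Also open, as far as these compounds go, is whether a longer chain carrying the hydroxycarbamoyl group would go further than 2-(hydroxycarbamoyl)ethenyl does.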